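The compounds below may be only part of what the source reports. "The series", "measured", "known", "first", "only" and "open" are said of these compounds alone.

Measured so far in a functional assay on MCF7 cells (Homo sapiens) for cytotoxicity, read by MTT assay, with a stated time of 72 h; a higher number here means a weaker inhibitor, a lower number a stronger inhibitor:
compound 1 `Cc1cc(=O)n(-c2ccccc2C(F)(F)F)nc1C(=O)Nc1ccc(Oc2ncnc3ccsc23)cc1` gives 5550 nM;
compound 2 `Cc1cc(=O)n(-c2ccc(Br)cc2F)nc1C(=O)Nc1ccc(Oc2ncnc3ccsc23)cc1` gives 9360 nM;
compound 3 `Cc1ccc(-n2nc(C(=O)Nc3ccc(Oc4ncnc5ccsc45)cc3)c(C)cc2=O)cc1` gives 23800 nM.

Compound 3 has the highest number of the three, beyond the scatter from both others, as the steps of a 4.3-fold higher number from compound 1 to compound 3 (0.63 log units; beyond the scatter) and a 2.5-fold higher number from compound 2 to compound 3 (0.41 log units; beyond the scatter) show; the step of a 1.7-fold higher number from compound 1 to compound 2 (0.23 log units; within the scatter) stays within the scatter. Compound 4 `Cc1cc(=O)n(-c2ccc(F)cc2)nc1C(=O)Nc1ccc(Oc2ncnc3ccsc23)cc1` differs from compound 3 only in one place: fluoro in place of methyl on an aromatic carbon. The nearest guide is the step of a 2.5-fold higher number from compound 2 to compound 3 (0.41 log units; beyond the scatter), where a halogen-bearing ring went to a methyl-bearing ring; the present change runs back toward a halogen, so a modest drop in this assay is expected, a 2.0-fold lower number from compound 3 to compound 4 (0.30 log units; within the scatter). Compound 4 is therefore estimated at 12000 nM, with a range from 5000 nM to 30000 nM.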

Compound 4, half-maximal inhibitory concentration: 4400 nM
Beside the measured number, compound 4's estimate is 2.7-fold (0.44 log units) above it; the whole stated range lies above it.
By their numbers in this assay, from the lowest: compounds 4, 1 and 2 (each within the scatter of the next, the first and the last beyond it); then compound 3.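

In this assay, fluoro in place of methyl at this one ring position, para to a large group, gives a 5.4-fold lower number from compound 3 to compound 4 (0.73 log units; beyond the scatter) and so shows that a single-atom change here can move the number beyond the scatter. The simple 4-fluorophenyl ring also separates from the 4-bromo-2-fluorophenyl ring, with a 2.1-fold lower number from compound 2 to compound 4 (0.33 log units; beyond the scatter), but not from the 2-(trifluoromethyl)phenyl ring, with a 1.3-fold lower number from compound 1 to compound 4 (0.10 log units; within the scatter). Nothing shown here explains these shifts. Still open, as far as these compounds go, is what an amine or a carboxylic acid would do at this position, and whether any group there would give a lower number than fluoro.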